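Trimming One Carbon from a Pair at the Assay Limit

The compounds below may be only part of what the source reports. "The series", "measured", "known", "first", "only" and "open" are said of these compounds alone.

Compound 1 `CCCCCCCCCCn1cc(-c2nc3ccccc3cc2CCC)nn1`: > 100 ug/mL
Compound 2 `CCCCCc1cc2ccccc2nc1-c1cn(CCC(F)(F)C(F)(F)C(F)(F)C(F)(F)C(F)(F)C(F)(F)C(F)(F)C(F)(F)F)nn1`: > 100 ug/mL

Both measured compounds were run in a functional assay on HeLa cells (Homo sapiens) for cytotoxicity, read by MTT assay, with a stated time of 24 h; on this read-out higher numbers stand for weaker inhibition and lower numbers for stronger inhibition. In this assay compound 1 gives > 100 ug/mL, which is a limit of the assay rather than a number. In this assay compound 2 gives > 100 ug/mL, again a limit and not a measured number. Going by the values given here, both values therefore sit at the limit of > 100 ug/mL in this assay, at which 2 of the 2 values shown sit, so no step between measured compounds can be read from them.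

Compound 3 `CCCCc1cc2ccccc2nc1-c1cn(CCC(F)(F)C(F)(F)C(F)(F)C(F)(F)C(F)(F)C(F)(F)C(F)(F)C(F)(F)F)nn1` has not been measured in this assay. It differs from compound 2 by hydrogen in place of methyl on a saturated chain carbon, four bonds along the chain from an aromatic carbon. Among the compounds with values here, with no measured step to lean on, and with compound 2 itself only at a limit, the expected step from compound 2 to compound 3 is none beyond the scatter, estimated as a step that the limit leaves unreadable from compound 2 to compound 3. Compound 3 is expected to give about 150 ug/mL, estimated between 80 ug/mL and 400 ug/mL, and most likely to be reported once more only as a limit.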

Compound 3, half-maximal inhibitory concentration: 32.8 ug/mL
The estimate for compound 3 lay 4.6-fold (0.66 log units) above the measured number, outside the stated range (below it).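

In this assay, going by these compounds alone, the saturated chain carbon four bonds along the chain from an aromatic carbon proves to be a place where one carbon matters: the earlier compounds offered no readable step, whereas hydrogen in place of methyl there gives an at least 3.0-fold lower number from compound 2 to compound 3 (0.48 log units; beyond the scatter). With the rest of the structure unchanged, this single change is all that separates the two compounds. The size of the step remains a bound and not an exact measure, because its starting point is a limit of the assay: the limit of > 100 ug/mL in this assay, at which 2 of the 3 values shown sit.

Going by these compounds, whether an ethyl chain at this place would lower the number further, or whether an amine at the end of the butyl chain would keep the gain, stays open. Compound 1 differs from compound 3 in more than one place, so it cannot settle either question.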